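The compounds below may be only part of what the source reports. "The series", "measured", "known", "first", "only" and "open" are said of these compounds alone.

Compounds measured so far: compound 1 `COc1ccc(NC(=O)c2cn(-c3ccccc3)nc2-c2ccccc2)cc1` gives 1710 nM; compound 2 `COc1ccc(NC(=O)c2cn(-c3ccccc3)nc2-c2ccc(OC)cc2)cc1` gives 1770 nM; compound 3 `O=C(Nc1ccc(Cl)cc1)c1cn(-c2ccccc2)nc1-c1ccc(Cl)cc1` gives 3750 nM, all in a functional assay on MCF7 cells (Homo sapiens) for cytotoxicity, read by MTT assay, with a stated time of 48 h; a higher number here means a weaker inhibitor, a lower number a stronger inhibitor.

Compound 3 stands highest of the three, beyond the scatter from both compound 1 and compound 2. Compound 4 `COc1ccc(NC(=O)c2cn(-c3ccccc3)nc2-c2ccc(Cl)cc2)cc1` arises from compound 3 by methoxy in place of chloro on an aromatic carbon. Going by the values given here, no measured step swaps chloro for methoxy directly; the only measured step, a 1.0-fold higher number from compound 1 to compound 2 (0.01 log units; within the scatter), concerns the other aromatic ring and stays within the scatter. Since compound 1 and compound 2, which both carry methoxy where compound 4 does, sit lower than compound 3, a modest drop is expected, a 1.7-fold lower number from compound 3 to compound 4 (0.23 log units; within the scatter). Compound 4 is therefore estimated at 2200 nM, ranging from 1100 nM to 4500 nM.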

Compound 4, half-maximal inhibitory concentration: 1550 nM
Compound 4: the middle estimate sits 1.4-fold (0.15 log units) above what was measured, and the stated range covers the measured number.
By their numbers in this assay, from the lowest: compounds 4, 1 and 2 (each within the scatter of the next); then compound 3.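

Replacing the (4-chlorophenyl)amino group with the (4-methoxyphenyl)amino group, with the rest of the molecule unchanged, gives a 2.4-fold lower number from compound 3 to compound 4 (0.38 log units; beyond the scatter), the first single-place change shown to exceed the scatter. With the (4-methoxyphenyl)amino group kept, chloro on the other phenyl ring cannot be told apart from methoxy, a 1.1-fold lower number from compound 2 to compound 4 (0.06 log units; within the scatter), or from hydrogen, a 1.1-fold lower number from compound 1 to compound 4 (0.04 log units; within the scatter). Nothing shown accounts for this contrast between the two places.

Still open, on these data alone, is how an amine or a carboxylic acid would behave in place of methoxy on the (4-methoxyphenyl)amino group. Also open, as far as these compounds go, is whether the chloro-to-methoxy step there would hold with methoxy or hydrogen on the other phenyl ring.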